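Lengthening the chain of compound 3 by six carbons

The source may report more compounds than this note shows. Statements on the series, on what has been measured and on what is new or still open speak of the compounds shown alone.

Measured so far:
compound 1 `Cc1c(N(C)C)nc(CCCCCCCCCCO)c(O)c1C` — 50%
compound 2 `CCCCCCCCCCCCCCCCCCCc1c(C)c(N(C)C)nc(C)c1O` — 64%
compound 3 `CCCCCCCCCCc1nc(N(C)C)c(C)c(C)c1O` — 90%

In a functional assay on cells (Lymphocyte, Homo sapiens) for inhibition, read by flow cytometry, using a membrane potential dye, with a stated time of 16 h, tested at 500 nM (on this read-out higher numbers stand for a stronger effect at the one concentration tested and lower numbers for a weaker effect), compound 3 stands highest of the three numbers; compound 2 is the nearest, and compound 1 the furthest, both beyond the scatter. Going by the values given here, the only step between compounds that differ in one place is a number 40 percentage points higher from compound 1 to compound 3 (beyond the scatter), where the chain of compound 1 ends in a hydroxy group and the chain of compound 3 in a hydrogen.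

Compound 4 `CCCCCCCCCCCCCCCCc1nc(N(C)C)c(C)c(C)c1O` has not yet been measured in this assay. It differs from compound 3 in one place: hexyl in place of hydrogen on a saturated chain carbon, ten or more bonds along the chain from an aromatic carbon. Among the compounds with values here, no measured step shows exactly this change. Compound 2, which carries a much longer chain than compound 3 on a different carbon of the shared core, gives a lower number than compound 3, but since its core substitution also differs, its value can only be noted, not used as a step. Because compound 3 already gives 90%, there is little room to rise. A small decrease or no change beyond the scatter is expected: compound 4 is estimated at 78% (range 55% to 95%), a step of a number 12 percentage points lower from compound 3 to compound 4 (beyond the scatter) expected from compound 3 to compound 4.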

Compound 4, a percentage reported as activity, at one concentration (the size of the read-out at that concentration, not a potency): 92%
Compound 4: the middle estimate sits 14 percentage points below what was measured, within the range that was stated.
By their numbers in this assay, from the lowest: compound 1; then compound 2; then compounds 3 and 4 (each within the scatter of the next).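

In this assay hexyl in place of hydrogen on a saturated chain carbon, ten or more bonds along the chain from an aromatic carbon, gives a number 2 percentage points higher from compound 3 to compound 4 (within the scatter) and so, at this place, the read-out does not tell the longer chain from the shorter one. The hydroxy at the chain end now stands out against two chains that lack it: a number 42 percentage points higher from compound 1 to compound 4 (beyond the scatter) joins a number 40 percentage points higher from compound 1 to compound 3 (beyond the scatter) as a large step, so the low number of compound 1 goes with that hydroxy in both comparisons. Nothing measured alongside these numbers explains either result.

Going by these compounds, compound 3 at 90% and compound 4 at 92% both sit high on a read-out taken at a single concentration, so any difference in potency between them stays open, and only a test over a range of concentrations could show one. Also open, on these data alone, is whether a longer chain still, or a chain ending in an amine or a carboxylic acid instead of a hydroxy, would hold the number at this place or lower it as the hydroxy does.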